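A few compounds are considered here, and "the series" means these few. Any claim that something is new, unique, unknown or untested is made for them only; others in the source may bear on it.

Compound 1 `CNC(=O)c1cnc(NC(=O)NC2CCCCC2)n2nc(-c3ccco3)nc12` — in a functional assay on CHO cells for antagonist activity at adenosine receptor A2b (Homo sapiens) (a higher number here means a weaker inhibitor, a lower number a stronger inhibitor), compound 1 gives > 30000 nM, which is a limit of the assay and not a number.
Compound 2 `CCOC(=O)c1cnc(NC2CC2)n2nc(-c3ccco3)nc12` — in this assay compound 2 gives 2260 nM.
Compound 3 `CCOC(=O)c1cnc(NCC2CCCCC2)n2nc(-c3ccco3)nc12` — in this assay compound 3 gives > 10000 nM, again a limit rather than a number.

From the compounds shown here alone, compound 3 therefore stands at the limit of > 10000 nM in this assay, at which 1 of the 3 values shown sits, so its true value is unknown beyond that boundary; compound 1 sits at the other boundary, (the limit of > 30000 nM in this assay, at which 1 of the 3 values shown sits), and only compound 2 has a measured number. Going by the values given here, the one step that involves compound 3 is an at least 4.4-fold higher number from compound 2 to compound 3 (0.64 log units; beyond the scatter), so enlarging the group on that ring nitrogen from cyclopropyl to cyclohexylmethyl cost potency.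

Compound 4 `CCOC(=O)c1cnc(N2CCCCC2)n2nc(-c3ccco3)nc12` differs from compound 3 in one place: piperidin-1-yl in place of (cyclohexylmethyl)amino on an aromatic carbon. The six-membered ring is now joined to the core directly through its own nitrogen, the linking methylene and the amine hydrogen are gone, and the group is smaller.

Among the compounds with values here, no measured step covers this exact exchange. Within the data shown here, the only neighbouring step shows that a bulkier group weakened inhibition, and compound 4 moves part of the way back in size, so a modest gain, or no change beyond the scatter, is expected: an at least 1.2-fold lower number from compound 3 to compound 4 (0.09 log units; that floor lies within the scatter). Compound 4 is estimated at 8000 nM, somewhere between 2500 nM and 30000 nM, with a real chance that only a limit is reported.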

Compound 4, inhibition constant: > 10000 nM
Compound 4 gave a limit, no number; the forecaster's own chance of this, stated with the estimate: 40%; middle value at least 1.2-fold (0.09 log units) away from the limit.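

In this assay, compound 4 joins compound 3 at the same limit of the assay, which is not a number: the limit of > 10000 nM in this assay, at which 2 of the 4 values shown sit. The step between these two compounds therefore cannot be read, so the data do not tell whether piperidin-1-yl is better or worse than (cyclohexylmethyl)amino. Going by these compounds alone, what can be read is the comparison with the one measured compound of this kind: piperidin-1-yl in place of cyclopropylamino gives an at least 4.4-fold higher number from compound 2 to compound 4 (0.64 log units; beyond the scatter), so inhibition is lost at this carbon both with a larger group that keeps its hydrogen-bond donor, as in compound 3, and with one that has none, as in compound 4.

How weak compound 3 and compound 4 really are stays hidden behind their limit, so the two groups cannot be ranked. From the compounds shown here alone, it also remains open whether a smaller group on this carbon, such as a plain amino group or a methylamino group, would give a lower number than compound 2, at 2260 nM, or whether a morpholine ring would behave like piperidin-1-yl.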